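Ethoxy in place of methoxy on the triazole aryl group

This account rests on a few compounds, and the source may have more. Where it says the series, first, only, none or still open, it means among the compounds named here.

The series shares one core; the aromatic nitrogen of its triazole carries an aryl group that is varied. Compound 1 `Cc1ccccc1-n1nncc1CN1C(=O)C2(C(C#N)=C(N)Oc3c(N)cc4nc5ccccc5nc4c32)c2ccccc21` carries 2-methylphenyl there. In a functional assay on HCT-116 cells (Homo sapiens) for antiproliferative activity, read by MTT assay, with a stated time of 48 h (on this read-out higher numbers stand for weaker inhibition and lower numbers for stronger inhibition), compound 1 gives > 50000 nM, which is a limit of the assay and not a number. Compound 2 `N#CC1=C(N)Oc2c(N)cc3nc4ccccc4nc3c2C12C(=O)N(Cc1cnnn1-c1cccc(Br)c1)c1ccccc12` carries 3-bromophenyl, and in this assay compound 2 gives 26100 nM. Compound 3 `COc1ccc(-n2nncc2CN2C(=O)C3(C(C#N)=C(N)Oc4c(N)cc5nc6ccccc6nc5c43)c3ccccc32)cc1` carries 4-methoxyphenyl. In this assay compound 3 gives > 50000 nM, again a limit rather than a number. Compound 3 thus stands at the floor of resolution of this assay, and the limit of > 50000 nM in this assay, at which 2 of the 3 values shown sit, shows that this is where most of the series sits. The measured steps read an at least 1.9-fold lower number from compound 1 to compound 2 (0.28 log units; that floor lies within the scatter), an at least 1.9-fold higher number from compound 2 to compound 3 (0.28 log units; that floor lies within the scatter) and a step that the two limits leave unreadable from compound 1 to compound 3; the first two lie within scatter at their floor, the third is unreadable.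

Compound 4 `CCOc1ccc(-n2nncc2CN2C(=O)C3(C(C#N)=C(N)Oc4c(N)cc5nc6ccccc6nc5c43)c3ccccc32)cc1` differs from compound 3 by methyl in place of hydrogen on a saturated chain carbon bound to an oxygen on an aromatic ring. For the measured compounds named here, no measured step touches this part of the molecule, so no direction is supported. The expectation is a step that the limit leaves unreadable from compound 3 to compound 4, nothing beyond the scatter. Compound 4 is estimated at 70000 nM, within 30000 nM to 200000 nM, most likely reported only as a limit.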

Compound 4, half-maximal inhibitory concentration: > 50000 nM
Compound 4: a limit, no number; the forecaster's own chance of this, stated with the estimate: 75%; the middle value does not contradict the limit.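

In this assay compound 4, with 4-ethoxyphenyl on the aromatic nitrogen, gives > 50000 nM, which is a limit and not a number. For the compounds shown here, the steps to compound 4 from compound 1 and from compound 3 cannot be read, both ends being limits, and the one readable step is an at least 1.9-fold higher number from compound 2 to compound 4 (0.28 log units; that floor lies within the scatter). Going from methoxy to ethoxy therefore yields no number, compound 2 remains the only compound with one, and the series stays concentrated at a single limit: the limit of > 50000 nM in this assay, at which 3 of the 4 values shown sit.

Still open, going by these compounds, is whether a chain longer than ethoxy, or an amine or a carboxylic acid in its place on the phenyl group, gives a number at all in this assay. Also open, on these data alone, is whether 4-bromophenyl reads like compound 2 or stays at the limit like compound 3 and compound 4.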